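Adding a Fluorine to a Strong Sulfonamide Inhibitor

The source may report more compounds than this note shows. Statements on the series, on what has been measured and on what is new or still open speak of the compounds shown alone.

Measured so far:
Compound 1, `O=C(/C=C/c1cccnc1)NCCCCCc1ccc(S(=O)(=O)Nc2ccccc2)cc1`, gives 408 nM in a functional assay on Huh-7 cells (Homo sapiens) for inhibition, read by CCK-8 assay, with a stated time of 72 h; a higher number here means a weaker inhibitor, a lower number a stronger inhibitor.
Compound 2, `O=C(/C=C/c1cccnc1)NCCCCCCc1cccc(S(=O)(=O)Nc2ccccc2)c1`, gives 2.82 nM in this assay.

Within the data shown here, only two compounds have been measured, and compound 2 stands at the lowest number of the two. Its nearest neighbour on the numbers, compound 1, sits far higher, a gap well beyond the usual scatter of repeated measurements. Among the measured compounds shown here, the two differ in several places at once, so no single step between them can be drawn; their values show only that compound 2 is the more potent of the pair.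

Compound 3, `O=C(/C=C/c1cccnc1)NCCCCCCc1cccc(S(=O)(=O)Nc2ccc(F)cc2)c1`, has not yet been measured. It is built on compound 2 with one change: fluoro in place of hydrogen on an aromatic carbon. For the measured compounds named here, no measured pair shows what a fluoro in place of hydrogen does here, so there is no step to lean on. The expectation is that the step of a 1.1-fold higher number from compound 2 to compound 3 (0.03 log units; within the scatter) is small, in no firm direction, and within the scatter. Compound 3 is therefore estimated at 3 nM, with a range from 1 nM to 10 nM.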

Compound 3, half-maximal inhibitory concentration: 4.28 nM
Estimate against measurement, compound 3: 1.4-fold (0.15 log units) below; measured number inside the range.
By their numbers in this assay, from the lowest: compounds 2 and 3 (each within the scatter of the next); then compound 1.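

Placing fluoro in place of hydrogen on the phenyl of the phenylsulfamoyl group gives a 1.5-fold higher number from compound 2 to compound 3 (0.18 log units; within the scatter) in this assay and is the first change here that can be read on its own, as compounds 2 and 3 differ in one place only. The step shows that this aromatic carbon, para to a large group, can carry a fluoro while the pair stays within the scatter of each other, so the low-nanomolar level of compound 2 is kept in compound 3. Nothing measured on these compounds offers an explanation for this result.

A single fluoro on a single carbon leaves open what a chloro, a methoxy, a trifluoromethyl, an amine or a carboxylic acid would do on that same carbon, and what a fluoro would do elsewhere on the ring. The large gap between compound 1 and the other two cannot be read as a step, since compound 1 differs from them in more than one place, so the length of the chain and its place on the ring remain untangled.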